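A few compounds are considered here, and "the series" means these few. Any claim that something is new, unique, unknown or untested is made for them only; others in the source may bear on it.

Working notes on the series. In a functional assay on NCI-H1975 cells (Homo sapiens) for antiproliferative activity, read by MTT assay, with a stated time of 72 h (on this read-out higher numbers stand for weaker inhibition and lower numbers for stronger inhibition), compound 1 `COc1cc2ncnc(Nc3cccc(Br)c3)c2cc1OCCCCC(=O)Nc1ccc(S(N)(=O)=O)cc1` gives 11400 nM, the lower of the two numbers available. Compound 2 `COc1cc2ncnc(Nc3cccc(Cl)c3)c2cc1OCCCCC(=O)Nc1ccc(S(N)(=O)=O)cc1` gives 33200 nM. Compound 3 `COc1cc2ncnc(Nc3ccc(F)cc3)c2cc1OCCCCC(=O)Nc1ccc(S(N)(=O)=O)cc1` gives only a limit of the assay, > 40000 nM.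

The next entry is compound 4 `COc1cc2ncnc(Nc3ccc(Cl)cc3)c2cc1OCCCCC(=O)Nc1ccc(S(N)(=O)=O)cc1`, not yet measured in this assay. Its difference from compound 1 is 4-chlorophenyl in place of 3-bromophenyl on a nitrogen on an aromatic ring.

Among the compounds with values here, three measured steps bear on this change. Chloro in place of bromo gives a 2.9-fold higher number from compound 1 to compound 2 (0.46 log units; beyond the scatter), which compound 4 partly shares. The change of the same aryl group in compound 3 gives an at least 3.5-fold higher number from compound 1 to compound 3 (0.54 log units; beyond the scatter), also beyond the scatter. The remaining step, an at least 1.2-fold higher number from compound 2 to compound 3 (0.08 log units; that floor lies within the scatter), has a floor within the scatter and so sets no order between those two compounds.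

Given a 2.9-fold higher number from compound 1 to compound 2 (0.46 log units; beyond the scatter) and an at least 3.5-fold higher number from compound 1 to compound 3 (0.54 log units; beyond the scatter), a modest step to a higher number is expected, beyond the scatter. The expected step is a 2.6-fold higher number from compound 1 to compound 4 (0.42 log units; beyond the scatter). Compound 4 may also return only a limit. For compound 4 the estimate is 30000 nM, with an expected range of 14000 nM to 50000 nM.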

Compound 4, half-maximal inhibitory concentration: 31800 nM
The estimate for compound 4 lay 1.1-fold (0.03 log units) below the measured number, within the range that was stated.
By their numbers in this assay, from the lowest: compound 1; then compounds 4 and 2 (each within the scatter of the next). At a limit, above all of these: compound 3.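

In this assay, within the data shown here, 4-chlorophenyl in place of 3-bromophenyl gives a 2.8-fold higher number from compound 1 to compound 4 (0.45 log units; beyond the scatter), the first exact number for a 4-substituted aryl group, and this step is modest. With chloro held constant, 4-chlorophenyl in place of 3-chlorophenyl gives a 1.0-fold lower number from compound 2 to compound 4 (0.02 log units; within the scatter), so compounds 2 and 4 cannot be told apart here, and among compounds 1, 2 and 4 only compound 1, with its 3-bromophenyl group, stands apart, as a 2.9-fold higher number from compound 1 to compound 2 (0.46 log units; beyond the scatter) also shows. Chloro in place of fluoro gives an at least 1.2-fold lower number from compound 3 to compound 4 (0.09 log units; that floor lies within the scatter), and this floor sets no order between the two compounds because compound 3 gives only a limit of the assay: the limit of > 40000 nM in this assay, at which 1 of the 4 values shown sits.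

As far as these compounds go, whether bromo keeps its edge over chloro as 4-bromophenyl, or whether 3-iodophenyl or 3-methylphenyl would extend the difference seen for compound 1, remains open. The compounds shown also say nothing about a shorter or longer chain at the amide, or about a carboxylic acid in place of the sulfonamide.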